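Farnesoid X receptor agonists: an acidic pyridine variant

The compounds below may be only part of what the source reports. "The series", "measured", "known", "first", "only" and "open" are said of these compounds alone.

Measured so far:
Compound 1 `Cn1cc(C(=O)O)c2ccc(N3C(=O)CCc4cc(OCc5c(-c6c(Cl)cccc6Cl)noc5C5CC5)ccc43)cc21` – 43 nM
Compound 2 `Cn1nc(C(=O)O)c2ccc(N3C(=O)CCc4cc(OCc5c(-c6c(Cl)cccc6Cl)noc5C5CC5)ccc43)cc21` – 41 nM
Compound 3 `O=C1CCc2cc(OCc3c(-c4c(Cl)cccc4Cl)noc3C3CC3)ccc2N1c1ncc(O)cc1F` – 9 nM

Of the compounds shown here, three share the same core and have been tested in an assay on isolated protein for agonist activity at Bile acid receptor (Homo sapiens), read by AlphaScreen, with a stated time of 1 h; on this read-out higher numbers stand for an effect only at larger amounts of compound and lower numbers for an effect already at smaller amounts. Compound 1 gives 43 nM and compound 2 gives 41 nM; these two values lie within the scatter of each other. Compound 3 gives 9 nM, the lowest of the three numbers, and its gap to compound 2 and to compound 1 lies beyond the scatter in both cases.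

The next compound, compound 4 `O=C(O)c1cnc(N2C(=O)CCc3cc(OCc4c(-c5c(Cl)cccc5Cl)noc4C4CC4)ccc32)c(Cl)c1`, has not yet been measured. It differs from compound 3 by a group of 10 heavy atoms (6 carbon, 1 nitrogen, 2 oxygen, 1 chlorine; one six-membered aromatic ring with 1 hetero atom) in place of a group of 8 heavy atoms (5 carbon, 1 nitrogen, 1 oxygen, 1 fluorine; one six-membered aromatic ring with 1 hetero atom), on an amide-type nitrogen in a ring.

For the measured compounds named here, no step between measured compounds matches this change, so the direction is uncertain. The expectation rests on compound 1 giving 43 nM and compound 2 giving 41 nM, both weaker than compound 3. Compound 4 is therefore expected to show a moderate step toward a higher number, a 2.2-fold higher number from compound 3 to compound 4 (0.35 log units; beyond the scatter), possibly still within the scatter. The estimate for compound 4 in this assay is 20 nM, with a range from 6 nM to 70 nM.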

Compound 4, half-maximal effective concentration: 13 nM
Compound 4: the middle estimate sits 1.5-fold (0.19 log units) above what was measured; low and high end bracket the measured number.
By their numbers in this assay, from the lowest: compounds 3 and 4 (each within the scatter of the next); then compounds 2 and 1 (each within the scatter of the next).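

Putting the 5-carboxy-3-chloropyridin-2-yl group on the amide-type nitrogen in a ring, in place of the group carrying a fluorine and a hydroxyl, gives in this assay a 1.4-fold higher number from compound 3 to compound 4 (0.16 log units; within the scatter). For the compounds shown here, this shows that the position can hold a carboxylic acid on a single six-membered aromatic ring with 1 hetero atom while the number stays level with that of the hydroxyl-bearing group, something the earlier compounds could not show. Compound 1 at 43 nM and compound 2 at 41 nM also carry a carboxylic acid, but on a different group at this place, so the acid alone does not go with their printed numbers, and nothing shown here bears on why the values fall as they do.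

The chlorine and the carboxylic acid enter together in this one step, so the compounds shown do not separate what each contributes. Also open, on these data alone, is whether a methyl ester, a primary amide or a tetrazole in place of the carboxylic acid would keep the number in this range in this assay.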